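Methoxyaryl Ketone in Place of Dichloroaryl Ketone

The compounds below may be only part of what the source reports. "The series", "measured", "known", "first", "only" and "open" are said of these compounds alone.

Compound 1 `COc1cc(-c2cc(/C=C/C(=O)c3ccc(Cl)c(Cl)c3)[nH]n2)cc(OC)c1OC`: > 100000 nM in a functional assay on UO-31 cells (Homo sapiens) for inhibition, read by sulforhodamine B assay, with a stated time of 48 h (a lower number here means a stronger inhibitor of growth, a higher number a weaker inhibitor of growth), a limit of the assay.
Compound 2 `COc1ccc(-c2cc(/C=C/C(=O)c3cc(OC)c(OC)c(OC)c3)[nH]n2)cc1OC`: 2590 nM in this assay.
Compound 3 `COc1ccc(-c2cc(/C=C/C(=O)c3ccc(N)cc3)[nH]n2)cc1`: 2560 nM in this assay.

Compound 1 stands apart from the other two: in this assay compound 1 reaches only a limit, with no number behind it, as the limit of > 100000 nM in this assay, at which 1 of the 3 values shown sits, shows. Compound 2 and compound 3, each carrying a methoxy-bearing or amino-bearing aryl ketone on the shared core, give values that sit within the scatter of each other, so no order between them can be claimed.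

Compound 4 `COc1ccc(C(=O)/C=C/c2cc(-c3cc(OC)c(OC)c(OC)c3)n[nH]2)cc1OC` differs from compound 1 in one place: 3,4-dimethoxyphenyl in place of 3,4-dichlorophenyl on a carbonyl carbon.

Going by the values given here, no measured step between two of the measured compounds is at hand, so the size of this change must be judged from the values alone. The expected step of an at least 33-fold lower number from compound 1 to compound 4 (1.52 log units; beyond the scatter) is large and toward stronger growth inhibition, well beyond the scatter, because compound 2 with its methoxy-bearing ketone gives 2590 nM and compound 3 gives 2560 nM, while compound 1 with the dichlorophenyl ketone gives no number at all. Compound 4 is therefore estimated at 3000 nM in this assay. The estimated range for compound 4 runs from 800 nM to 15000 nM.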

Compound 4, concentration for total growth inhibition: 2570 nM
Compound 4: middle estimate off by 1.2-fold (0.07 log units), on the high side; measured number inside the range.
By their numbers in this assay, from the lowest: compounds 3, 4 and 2 (each within the scatter of the next). At a limit, above all of these: compound 1.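

On the carbonyl carbon of the shared core, 3,4-dimethoxyphenyl in place of 3,4-dichlorophenyl gives an at least 38-fold lower number from compound 1 to compound 4 (1.59 log units; beyond the scatter) in this assay, and this is the only one-place step among the compounds shown. The earlier compounds shown here differed from compound 1 in more than one place, so they could not tie its result to this position, whereas this pair shows that the aryl group on the carbonyl carbon alone decides between a measurable value and none. Compound 1 remains at a limit of the assay, so the step has a lower bound and no exact size: the limit of > 100000 nM in this assay, at which 1 of the 4 values shown sits.

The two aryl groups differ at both of their substituents, so the compounds shown leave open whether a single methoxy group or a single chlorine would be enough to move the value, and how an unsubstituted phenyl would compare. They also leave open whether other groups at this place, such as an amine or a carboxylic acid on the same aryl ring, would keep a value of this order in this assay.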